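Swapping a methoxy for a cyano on compound 1's pyridine

The source may hold more compounds than are shown below. What is called first, only, known or untested is meant among the compounds shown, and "the series" means these compounds.

Going by the values given here, compound 1 `COc1cncc(C2=CC3CC(C2)CN(C)C3)c1` is the strongest of the two compounds measured so far: in an in vitro assay on SH-EP1 cells for displacement of a labelled ligand from Neuronal acetylcholine receptor; alpha4/beta2 (Homo sapiens) (a higher number here means a weaker inhibitor, a lower number a stronger inhibitor), compound 1 gives 0.6 nM. Among the compounds with values here, the only comparison available is compound 2 `COc1cc(C2=CC3CC(C2)CN(C)C3)cnc1Cl`, which in this assay gives 4.4 nM; the single step, chloro in place of hydrogen on an aromatic carbon, is a 7.3-fold higher number from compound 1 to compound 2 (0.87 log units; beyond the scatter). Compound 3 `CN1CC2C=C(c3cncc(C#N)c3)CC(C2)C1` differs from compound 1 in another way: cyano in place of methoxy on an aromatic carbon. Within the data shown here, no measured step tells how a cyano compares with a methoxy at this place, so the one step known can only indicate that changing a substituent on this ring shifts the number modestly rather than drastically. On that basis the expected change is a 3.3-fold higher number from compound 1 to compound 3 (0.52 log units; beyond the scatter). Compound 3 is therefore estimated to give about 2 nM in this assay, with a likely range from 0.5 nM to 8 nM.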

Compound 3, inhibition constant: 24 nM
The estimate for compound 3 lay 12-fold (1.08 log units) below the measured number, outside the stated range (above it).
By their numbers in this assay, from the lowest: compound 1; then compound 2; then compound 3.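

In this assay, going by these compounds alone, cyano in place of methoxy is a 40-fold higher number from compound 1 to compound 3 (1.60 log units; beyond the scatter), a large step, whereas the only earlier step, a chloro in place of hydrogen elsewhere on the ring, was modest. The number at this aromatic carbon, two atoms from the ring nitrogen, can therefore depend strongly on which small group sits there: methoxy and cyano match in heavy atoms, hydrogen-bond donors, hydrogen-bond acceptors and net charge, so these counts alone do not predict the result. No available measurement explains why the two groups differ so much.

The compounds shown leave open how plain hydrogen at this carbon would compare with methoxy and cyano. They also leave open whether an amine, a hydroxyl or an ethoxy there would give a number closer to compound 1 or to compound 3.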